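Swapping 4-chlorophenyl for 3,5-dimethylphenyl on a sulfur

The source may report more compounds than this note shows. Statements on the series, on what has been measured and on what is new or still open speak of the compounds shown alone.

Among the measured compounds shown here, in a functional assay on HCT-116 cells (Homo sapiens) for inhibition, read by CCK-8 assay, with a stated time of 72 h, tested at 2 uM (on this read-out lower numbers stand for less inhibition of growth and higher numbers for more inhibition of growth at the one concentration tested), compound 2 `Nc1ccccc1NC(=O)c1ccc(CSc2ccc(Cl)cc2)cc1` gives 17.5%, the lower of the two numbers so far, while compound 1 `COc1ccc(SCc2ccc(C(=O)Nc3ccccc3N)cc2)cc1` gives 73.3%. Compound 3 `Cc1cc(C)cc(SCc2ccc(C(=O)Nc3ccccc3N)cc2)c1` differs from compound 2 as follows: 3,5-dimethylphenyl in place of 4-chlorophenyl on a sulfur. For the measured compounds named here, only one measured step bears on this change: a number 55.8 percentage points lower from compound 1 to compound 2 (beyond the scatter), a large one beyond the scatter, with chloro in place of methoxy on an aromatic carbon. Going by the values given here, compound 3 also loses the chloro, but no measured compound carries its 3,5-dimethylphenyl, so a smaller upward move is expected, estimated as a number 27.5 percentage points higher from compound 2 to compound 3 (beyond the scatter). For compound 3 the expected value is 45%, within an estimated range of 20% to 70%.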

Compound 3, percent growth inhibition at one concentration: 3.22%
Compound 3: the middle estimate sits 41.8 percentage points above what was measured; measured number outside the range, below it.
By their numbers in this assay, from the lowest: compound 3; then compound 2; then compound 1.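

Taking away the chloro did not raise the number at this position on the sulfur: in this assay, 3,5-dimethylphenyl in place of 4-chlorophenyl gave a further fall (a number 14.3 percentage points lower from compound 2 to compound 3 (beyond the scatter)). Set against 4-methoxyphenyl, the same group gave a far larger fall (a number 70.1 percentage points lower from compound 1 to compound 3 (beyond the scatter)), so of the three aromatic groups shown, only 4-methoxyphenyl gives a high number. Nothing available explains this difference.

On these data alone, what remains open is whether the methoxy group itself matters, and whether an ethoxy group or an amine on that ring would keep the high number.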